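A few compounds are considered here, and "the series" means these few. Any claim that something is new, unique, unknown or untested is made for them only; others in the source may bear on it.

Measured so far in an assay on SH-EP1 cells for agonist activity at Neuronal acetylcholine receptor; alpha4/beta2 (Homo sapiens), read by FLIPR and calcium flux; on this read-out lower numbers stand for an effect already at smaller amounts and higher numbers for an effect only at larger amounts of compound:
compound 1 `CCCC(=O)N1CC2CC(C1)N2`, 850 nM
compound 2 `O=C(C1CCC1)N1CC2CC(C1)N2`, 11000 nM
compound 3 `O=C(C1CC=CC1)N1CC2CC(C1)N2`, 17000 nM

Compound 2 gives the second highest of the three numbers in this assay; compound 3 gives a number close to it, within the scatter, while compound 1 gives a markedly lower number, beyond the scatter.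

The unmeasured compound 4 `C[C@@H]1C[C@H]1C(=O)N1CC2CC(C1)N2` differs from compound 2 in one place: 2-methylcyclopropyl in place of cyclobutyl on a carbonyl carbon.

Among the measured compounds shown here, only one measured step bears on this change, and only indirectly: a 13-fold higher number from compound 1 to compound 2 (1.11 log units; beyond the scatter) shows that closing the propyl chain into a cyclobutyl ring on the carbonyl carbon carried a large rise. Compound 3, with a further ring of the same kind on that carbon, sits with compound 2 within the scatter. Compound 4 keeps a ring there, but a smaller one with a methyl on it, and so is expected to stay near compound 2 in this assay, with at most a modest shift to a lower number, as a 1.6-fold lower number from compound 2 to compound 4 (0.20 log units; within the scatter).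

For compound 4 the value in this assay is therefore estimated at 7000 nM, within a range of 2200 nM to 22000 nM.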

Compound 4, half-maximal effective concentration: 2900 nM
For compound 4 the middle estimate is 2.4-fold (0.38 log units) above the measured one; the range from low to high includes it.
By their numbers in this assay, from the lowest: compound 1; then compound 4; then compounds 2 and 3 (each within the scatter of the next).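

In this assay, putting 2-methylcyclopropyl in place of cyclobutyl on the carbonyl carbon gives a 3.8-fold lower number from compound 2 to compound 4 (0.58 log units; beyond the scatter) and so separates two groups with the same heavy-atom count, each carrying one carbon ring. A ring at this position therefore does not by itself hold the number at the level of compound 2, although the open propyl group remains ahead of this ring, with a 3.4-fold higher number from compound 1 to compound 4 (0.53 log units; beyond the scatter) in the same assay. Nothing available explains the difference between the two rings.

Still open, going by these compounds, is whether the lower number belongs to the three-membered ring or to its methyl, a question that plain cyclopropyl on the carbonyl carbon would address. The compounds shown also leave open how the other stereoisomers of 2-methylcyclopropyl compare with compound 4.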